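Replacing furan-2-yl with methoxy on the shared core

The compounds below may be only part of what the source reports. "The series", "measured", "known", "first", "only" and "open" are said of these compounds alone.

For the measured compounds named here, in a functional assay on A549 cells (Homo sapiens), read by MTT assay, with a stated time of 3 days (on this read-out higher numbers stand for weaker inhibition and lower numbers for stronger inhibition), compound 1 `CN(C)c1ncnc2[nH]cc(Sc3cccs3)c12` gives 19800 nM and compound 2 `c1coc(-c2ncnc3[nH]cc(Sc4cccs4)c23)c1` gives 11400 nM, so compound 2 stands within the scatter of the only other measured value. Compound 3 `COc1ncnc2[nH]cc(Sc3cccs3)c12`, not yet measured, carries methoxy in place of furan-2-yl on an aromatic carbon. Going by the values given here, the one measured step at this place, a 1.7-fold lower number from compound 1 to compound 2 (0.24 log units; within the scatter), stayed within the scatter, and no larger change is therefore expected here. The expected step is a 1.3-fold higher number from compound 2 to compound 3 (0.12 log units; within the scatter), which would not exceed the scatter. For compound 3 the estimated value is 15000 nM, with an expected range of 6000 nM to 40000 nM.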

Compound 3, half-maximal inhibitory concentration: 21500 nM
Compound 3: the middle estimate sits 1.4-fold (0.16 log units) below what was measured; the measured number falls inside the stated range.
By their numbers in this assay, from the lowest: compounds 2, 1 and 3 (each within the scatter of the next).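

Replacing furan-2-yl with methoxy in this assay removes the ring and leaves 2 heavy atoms in place of 5, yet gives a 1.9-fold higher number from compound 2 to compound 3 (0.28 log units; within the scatter). Methoxy in place of dimethylamino gives a 1.1-fold higher number from compound 1 to compound 3 (0.04 log units; within the scatter), so the three groups on this aromatic carbon all stand within the scatter of one another. On these data alone, whether a primary amine, a carboxylic acid or a longer chain such as butoxy at this carbon would give a step beyond the scatter remains open. Nothing at hand bears on what lies behind these steps.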